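This account rests on a few compounds, and the source may have more. Where it says the series, first, only, none or still open, it means among the compounds named here.

Measured compounds in a functional assay on a cell-free system (plasma) for inhibition of thromboxane A2 receptor (Homo sapiens); a higher number here means a weaker inhibitor, a lower number a stronger inhibitor:
- compound 1, `CCCCCCSC[C@H]1C2CC[C@@H](O2)[C@H]1C/C=C\CCCC(=O)O`: 115000 nM; > 1000000 nM; > 1000000 nM (3 entries)
- compound 2, `CCCCCCCSC1C2CCC(O2)C1C/C=C\CCCC(=O)O`: 230000 nM; 35000 nM (2 entries)
- compound 3, `O=C(O)CCC/C=C\CC1C2CCC(O2)C1CSCCc1ccccc1`: 5500 nM

Among the compounds with values here, compound 3 is the only compound of the three that gives a single number in this assay; the other two carry several entries each. For compound 1 the repeated entries, (the several entries of compound 1 in this assay, 115000 nM; > 1000000 nM; > 1000000 nM (3 entries)), scatter widely and include limits. For compound 2 the repeated entries, (the several entries of compound 2 in this assay, 230000 nM; 35000 nM (2 entries)), also differ between themselves.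

Compound 4, `CCCCCCCSCC1C2CCC(O2)C1C/C=C\CCCC(=O)O`, has not been measured in this assay. It differs from compound 3 in one place: pentyl in place of phenyl on a saturated chain carbon, two bonds along the chain from a sulfur, so that the phenethyl on sulfur becomes heptyl. The chain-bearing analogue compound 1 sits far weaker in this assay than compound 3 does, so a large loss of potency is expected on going from the phenethyl to the open chain, well beyond the scatter: the step is estimated as an 18-fold higher number from compound 3 to compound 4 (1.26 log units; beyond the scatter). For compound 4 the value in this assay is expected at 100000 nM, in the range 15000 nM to 700000 nM, with a real chance that only a limit is reported.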

Compound 4, half-maximal inhibitory concentration: 42000 nM
The estimate for compound 4 lay 2.4-fold (0.38 log units) above the measured number, and the stated range covers the measured number.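

In this assay, within the data shown here, the swap of the phenethyl on sulfur for heptyl gives the first reading of this position between two compounds that differ in one place: pentyl in place of phenyl, on a saturated chain carbon two bonds along the chain from a sulfur, gives a 7.6-fold higher number from compound 3 to compound 4 (0.88 log units; beyond the scatter). The phenyl is therefore favoured over the open chain here, though compound 4 still gives a number rather than a limit. Compound 1 could not settle this, as its entries scatter widely and two of them are limits of the assay: the several entries of compound 1 in this assay, 115000 nM; > 1000000 nM; > 1000000 nM (3 entries)

Going by these compounds, whether the gain depends on the aromatic ring itself or on its distance from the sulfur remains open. Also open, on these data alone, is how a pyridyl ring, a chlorophenyl ring or a shorter benzyl group would read at this position.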